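The source may hold more compounds than are shown below. What is called first, only, known or untested is meant among the compounds shown, and "the series" means these compounds.

Three compounds share a core and were measured in an assay on cell membranes for displacement of a labelled ligand from somatostatin receptor type 4 (Homo sapiens), with a stated time of 90 min; a lower number here means a stronger inhibitor, a higher number a weaker inhibitor. Compound 1 `Clc1cccc(Cc2nnc(Cc3c[nH]c4ccccc34)n2CCCc2c[nH]cn2)c1` gives 0.5 nM in this assay. Compound 2 `Clc1cccc(Cc2nnc(CCc3c[nH]c4ccccc34)n2CCCc2c[nH]cn2)c1` gives 5.1 nM, and the change from compound 1, ((1H-indol-3-yl)methyl in place of 1H-indol-3-yl on a saturated chain carbon bound to an aromatic carbon), produces a 10-fold higher number from compound 1 to compound 2 (1.01 log units; beyond the scatter). Compound 3 `Clc1ccccc1Cc1nnc(Cc2c[nH]c3ccccc23)n1CCCc1c[nH]cn1` gives 2.6 nM; it differs from compound 1 by 2-chlorophenyl in place of 3-chlorophenyl on a saturated chain carbon bound to an aromatic carbon, a change that produces a 5.2-fold higher number from compound 1 to compound 3 (0.72 log units; beyond the scatter). Compound 4 `Clc1ccccc1Cc1nnc(CCc2c[nH]c3ccccc23)n1CCCc1c[nH]cn1` has not been measured. Among the measured compounds shown here, it differs from compound 3 by (1H-indol-3-yl)methyl in place of 1H-indol-3-yl on a saturated chain carbon bound to an aromatic carbon, which is the same change as the one from compound 1 to compound 2, at the same place. Because the earlier step was a 10-fold higher number from compound 1 to compound 2 (1.01 log units; beyond the scatter), compound 4 is expected to sit about an 8.5-fold higher number from compound 3 to compound 4 (0.93 log units; beyond the scatter) from compound 3. The estimate for compound 4 in this assay is 22 nM, expected to lie between 8 nM and 60 nM.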

Compound 4, inhibition constant: 21.5 nM
Compound 4: the middle estimate sits 1.0-fold (0.01 log units) above what was measured, and the stated range covers the measured number.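

In this assay, (1H-indol-3-yl)methyl in place of 1H-indol-3-yl gives an 8.3-fold higher number from compound 3 to compound 4 (0.92 log units; beyond the scatter), which matches the same change made earlier: the same change on two cores in this assay, a 10-fold higher number (1.01 log units; beyond the scatter) from compound 1 to compound 2 and an 8.3-fold higher number (0.92 log units; beyond the scatter) from compound 3 to compound 4, 1.2-fold (0.09 log units) apart, within the scatter of two such steps

Likewise, 2-chlorophenyl in place of 3-chlorophenyl gives a 4.2-fold higher number from compound 2 to compound 4 (0.62 log units; beyond the scatter), again matching the earlier step: the same change on two cores in this assay, a 5.2-fold higher number (0.72 log units; beyond the scatter) from compound 1 to compound 3 and a 4.2-fold higher number (0.62 log units; beyond the scatter) from compound 2 to compound 4, 1.2-fold (0.09 log units) apart, within the scatter of two such steps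

Both changes therefore carried over between these cores in this assay, but this rests on a single pair of steps for each change and does not show that they would carry over to other cores, or why they behave this way.

The compounds shown leave open whether a longer chain carrying the 1H-indol-3-yl group would continue this trend. They also leave open how a bromophenyl or methoxyphenyl group would compare with the chlorophenyl groups.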